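Pyridin-4-yl for 3-fluorophenyl: an expected solubility gain

The source may hold more compounds than are shown below. What is called first, only, known or untested is meant among the compounds shown, and "the series" means these compounds.

Compound 3 `Cc1cc(NCc2ccccn2)n2ncc(-c3cccc(F)c3)c2n1` was examined in a physicochemical assay for solubility, read by HPLC, using the shake flask method, measured as kinetic solubility, with a stated time of 2 h, at pH 7.4 (on this read-out lower numbers stand for lower solubility and higher numbers for higher solubility), where compound 3 gives 5000 nM. Of the two numbers recorded, this is the lowest. Compound 1 `Cc1cc(NCc2cccnc2)n2nc(C)c(-c3ccccc3)c2n1` gives 110000 nM in this assay, a higher number that lies beyond the scatter. Compound 2 `Cc1cc(NCc2ccccn2)n2ncc(-c3ccc(C(F)(F)F)cc3)c2n1` returns only a limit in this assay, < 5000 nM. Compound 4 `Cc1cc(NCc2ccccn2)n2ncc(-c3ccncc3)c2n1` differs from compound 3 in a single place: pyridin-4-yl in place of 3-fluorophenyl on an aromatic carbon. Within the data shown here, no measured pair shares this change, so its size is not yet known from the data. The step of a 3.0-fold higher number from compound 3 to compound 4 (0.48 log units; beyond the scatter) is expected to run toward higher solubility, beyond the scatter. Compound 4 is estimated at 15000 nM, with a range from 5000 nM to 60000 nM, pending the measurement.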

Compound 4, solubility: 161000 nM
The estimate for compound 4 lay 11-fold (1.03 log units) below the measured number, outside the stated range (above it).
By their numbers in this assay, from the lowest: compound 3; then compounds 1 and 4 (each within the scatter of the next).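

Pyridin-4-yl in place of 3-fluorophenyl on this aromatic carbon gives a 32-fold higher number from compound 3 to compound 4 (1.51 log units; beyond the scatter) in this assay, the first step at this position with a number on both sides. The group on this carbon alone can thus move the read-out by a large step. The lower end of this step lies at the same number as the limit returned by compound 2: the limit of < 5000 nM in this assay, at which 1 of the 4 values shown sits.

This one step does not separate the loss of the fluorine from the entry of the ring nitrogen. As far as these compounds go, whether an amine or a carboxylic acid at this place would give a similar step remains open.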